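A Smaller Ring in Place of a Bulky Amine

The source may hold more compounds than are shown below. What is called first, only, known or untested is meant among the compounds shown, and "the series" means these compounds.

In a functional assay on the whole organism with Rattus norvegicus as the target, in the maximal electroshock model (a lower number here means that less compound is needed, a higher number that more compound is needed for the effect), compound 1 `CNc1ncnc2c1ncn2Cc1cc(F)ccc1F` gives 4 mg/kg. Compound 2 `CC(C)(C)Nc1ncnc2c1ncn2Cc1ccccc1F` is known only by a limit of the assay: in this assay compound 2 gives > 50 mg/kg. This is the limit of > 50 mg/kg in this assay, at which 1 of the 2 values shown sits. Compound 3 `Fc1ccccc1Cn1cnc2c(N3CCC3)ncnc21` differs from compound 2 by azetidin-1-yl in place of (tert-butyl)amino on an aromatic carbon. Among the compounds with values here, no measured step of this kind exists, so the direction rests on the observation that compound 1, with a small amine, gives 4 mg/kg. A step toward a lower dose is expected from compound 2 to compound 3, an at least 2.5-fold lower number from compound 2 to compound 3 (0.39 log units; beyond the scatter). Compound 3 is estimated at 20 mg/kg, between 5 mg/kg and 60 mg/kg.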

Compound 3, dose for half-maximal effect: > 50 mg/kg
Compound 3: a limit, no number; the forecaster's own chance of this, stated with the estimate: 30%; middle value at least 2.5-fold (0.39 log units) from the limit.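

Compound 2 and compound 3 both sit at a limit rather than a number, so no step between them can be read: the limit of > 50 mg/kg in this assay, at which 2 of the 3 values shown sit.

The compounds shown leave open whether azetidin-1-yl in place of (tert-butyl)amino changes the dose needed in this assay at all.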